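A few compounds are considered here, and "the series" means these few. Any claim that something is new, unique, unknown or untested is made for them only; others in the source may bear on it.

Of the compounds shown here, two sharing one core have been measured so far in an ADME assay on L6 cells (Rattus norvegicus) for inhibition, read by resazurin assay, with a stated time of 72 h; on this read-out lower numbers stand for stronger inhibition and higher numbers for weaker inhibition. Compound 1 (`CC(=O)O[C@@H]1[C@H](OC(C)=O)[C@@H](CS(C)(=O)=O)O[C@H]1n1cnc2c(N)nc(Cl)nc21`) gives 114000 nM, and compound 2 (`CC(=O)NC[C@H]1O[C@@H](n2cnc3c(N)nc(F)nc32)[C@H](OC(C)=O)[C@@H]1OC(C)=O`) gives 138000 nM. These two numbers lie within the usual scatter of each other, so compound 2 stands level with compound 1, and both numbers are large.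

Compound 3 (`CC(=O)NC[C@H]1O[C@@H](n2cnc3c(N)nc(Cl)nc32)[C@H](OC(C)=O)[C@@H]1OC(C)=O`) differs from compound 2 in one place: chloro in place of fluoro on an aromatic carbon. Among the compounds with values here, no measured pair shows this swap alone. In this assay no step beyond the scatter is expected, in either direction: compound 1 already carries chloro on that carbon and gives 114000 nM. The expected change is a 1.3-fold lower number from compound 2 to compound 3 (0.10 log units; within the scatter). Compound 3 is estimated at 110000 nM, with an expected range of 50000 nM to 220000 nM.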

Compound 3, half-maximal inhibitory concentration: 190000 nM
Beside the measured number, compound 3's estimate is 1.7-fold (0.24 log units) below it; low and high end bracket the measured number.
By their numbers in this assay, from the lowest: compounds 1, 2 and 3 (each within the scatter of the next).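

In this assay, chloro in place of fluoro on the aromatic carbon between two ring nitrogen atoms gives a 1.4-fold higher number from compound 2 to compound 3 (0.14 log units; within the scatter), so with the rest of the molecule held fixed, these two halogens cannot be told apart at this position. Acetamido in place of methylsulfonyl on the saturated chain carbon gives a 1.7-fold higher number from compound 1 to compound 3 (0.22 log units; within the scatter), so this second place also shows no step beyond the scatter, now with chloro held fixed on the aromatic carbon. No evidence at hand bears on these results.

Going by these compounds, whether a methyl group or a nitrile on that aromatic carbon would move the number beyond the scatter remains open. The same holds for a carboxylic acid or a longer chain in place of acetamido on the saturated chain carbon.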